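The compounds below may be only part of what the source reports. "The series", "measured", "known", "first", "only" and "open" are said of these compounds alone.

Working notes on the series.

Compound 1 `C=CCOc1ccc2c(=O)c(-c3cc(OC)c(OC)cc3OC)coc2c1` is the reference point. In a functional assay on A-375 cells (Homo sapiens) for antiproliferative activity, read by MTT assay, with a stated time of 24 h (a lower number here means a stronger inhibitor, a higher number a weaker inhibitor), compound 1 gives 4750 nM, the highest number of the three measured compounds. Compound 2 `C#CCOc1ccc2c(=O)c(-c3cc(OC)c(OC)cc3OC)coc2c1` gives 3680 nM in this assay, and the change a 1.3-fold lower number from compound 1 to compound 2 (0.11 log units; within the scatter) stays within the scatter. Compound 3 `COc1cc(OC)c(-c2coc3cc(OCc4ccccc4)ccc3c2=O)cc1OC` gives 1640 nM in this assay; the step of a 2.9-fold lower number from compound 1 to compound 3 (0.46 log units; beyond the scatter) and the step of a 2.2-fold lower number from compound 2 to compound 3 (0.35 log units; beyond the scatter) both go beyond the scatter, in the direction of a lower number.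

Compound 4 `COc1cc(OC)c(-c2coc3cc(OCc4cccc(C(F)(F)F)c4)ccc3c2=O)cc1OC` has not been measured. It differs from compound 1 by 3-(trifluoromethyl)phenyl in place of vinyl on a saturated chain carbon bound to an oxygen on an aromatic ring. Among the compounds with values here, the step that bears on this change most directly is a 2.9-fold lower number from compound 1 to compound 3 (0.46 log units; beyond the scatter), since compound 3 already carries phenyl on that same chain carbon; no measured compound shows what the trifluoromethyl group on that phenyl adds. The expectation for compound 4 is therefore a lower number than compound 1 in this assay, of roughly the size seen for compound 3, so a 3.2-fold lower number from compound 1 to compound 4 (0.50 log units; beyond the scatter) is expected. The estimated value for compound 4 in this assay is 1500 nM, with a range from 600 nM to 4000 nM.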

Compound 4, half-maximal inhibitory concentration: 1140 nM
Estimate against measurement, compound 4: 1.3-fold (0.12 log units) above; low and high end bracket the measured number.
By their numbers in this assay, from the lowest: compounds 4 and 3 (each within the scatter of the next); then compounds 2 and 1 (each within the scatter of the next).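

Trifluoromethyl on the phenyl ring is tolerated in this assay: with a 1.4-fold lower number from compound 3 to compound 4 (0.16 log units; within the scatter), compound 3 and compound 4 cannot be told apart, so this substituent on an aromatic carbon neither adds to nor takes away from what the phenyl already gave. The substituted ring still keeps the series clear of the smaller groups, with a 4.2-fold lower number from compound 1 to compound 4 (0.62 log units; beyond the scatter) and a 3.2-fold lower number from compound 2 to compound 4 (0.51 log units; beyond the scatter), so the benefit of an aromatic ring on this chain carbon survives substitution. No measurement is available that would explain these steps.

Open, on these data alone, is whether an amine, a carboxylic acid or a longer chain on that same chain carbon would hold these numbers. Also open, as far as these compounds go, is whether a chlorine or a methoxy group on the phenyl ring would behave as trifluoromethyl does.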